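The source may report more compounds than this note shows. Statements on the series, on what has been measured and on what is new or still open speak of the compounds shown alone.

In a functional assay on MCF7 cells (Homo sapiens) for inhibition, read by sulforhodamine B assay, with a stated time of 48 h (on this read-out higher numbers stand for weaker inhibition of growth and lower numbers for stronger inhibition of growth), compound 3 (`CC1=CC[C@H](C(C)(C)NC(=S)N/N=C/c2ccccc2Cl)CC1`) gives 11000 nM, the higher of the two plain numbers seen, with compound 1 (`CC1=CC[C@H](C(C)(C)NC(=S)N/N=C/c2ccccc2)CC1`) at 8400 nM lying within the scatter of it, as the step of a 1.3-fold higher number from compound 1 to compound 3 (0.12 log units; within the scatter) shows. Compound 2 (`CC1=CC[C@H](C(C)(C)NC(=S)N/N=C/c2ccc(F)cc2)CC1`) reaches only a limit of this assay, > 100000 nM, as noted in the limit of > 100000 nM in this assay, at which 1 of the 3 values shown sits. Compound 4 (`CC1=CC[C@H](C(C)(C)NC(=S)N/N=C/c2ccc(Cl)cc2)CC1`) differs from compound 3 by 4-chlorophenyl in place of 2-chlorophenyl on a carbon with a double bond to nitrogen. Among the measured compounds shown here, two measured steps bear on this change: an at least 11-fold higher number from compound 1 to compound 2 (1.07 log units; beyond the scatter), and an at least 9.0-fold lower number from compound 2 to compound 3 (0.95 log units; beyond the scatter). Both point the same way, the chlorine in the 4-chlorophenyl group of compound 4 sitting where the fluorine of compound 2 sits. The fluorine and chlorine are different atoms, so the size of the step is uncertain, but a move towards a higher number, possibly again a limit, is expected. For compound 4 the estimate in this assay is 35000 nM, with a range from 9000 nM to 150000 nM, meaning an expected step of a 3.2-fold higher number from compound 3 to compound 4 (0.50 log units; beyond the scatter).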

Compound 4, concentration for 50% growth inhibition: 18300 nM
The estimate for compound 4 lay 1.9-fold (0.28 log units) above the measured number; measured number inside the range.
By their numbers in this assay, from the lowest: compounds 1, 3 and 4 (each within the scatter of the next, the first and the last beyond it). At a limit, above all of these: compound 2.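

In this assay, 4-chlorophenyl and 2-chlorophenyl on the carbon with a double bond to nitrogen cannot be told apart, the step being a 1.7-fold higher number from compound 3 to compound 4 (0.22 log units; within the scatter). The large loss seen with 4-fluorophenyl does not carry over to chloro in the same group, as shown by an at least 5.4-fold lower number from compound 2 to compound 4 (0.73 log units; beyond the scatter), so among these compounds that loss is seen only with fluoro, although chloro in place of hydrogen still has a modest cost, the step being a 2.2-fold higher number from compound 1 to compound 4 (0.34 log units; beyond the scatter). Compound 2 is held at a limit, not a number: the limit of > 100000 nM in this assay, at which 1 of the 4 values shown sits.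

Going by these compounds, what an amine, a methoxy group or a carboxylic acid on the aromatic ring would do stays open. So does whether bromo would follow chloro or fluoro.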